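This account rests on a few compounds, and the source may have more. Where it says the series, first, only, none or still open, it means among the compounds named here.

Measured compounds:
compound 1 `O=C(Nc1cccc(-n2cc(-c3ccncc3)c(-c3ccc(Cl)c(O)c3)n2)c1)Nc1cccc(C(F)(F)F)c1` — > 32500 nM
compound 2 `COc1cc(-c2nn(-c3cccc(NC(=O)Nc4cccc(C(F)(F)F)c4)c3)cc2-c2ccncc2)ccc1Cl` — > 50000 nM

In a functional assay on HOP-92 cells (Homo sapiens) for inhibition, read by sulforhodamine B assay, with a stated time of 48 h (a higher number here means that more compound is tolerated, a lower number that less compound is tolerated), compound 1 gives only a limit, > 32500 nM. Compound 2 also gives only a limit, > 50000 nM. Within the data shown here, the one measured step, a step that the two limits leave unreadable from compound 1 to compound 2, methyl in place of hydrogen on an oxygen on an aromatic ring, cannot be sized because the limit of > 32500 nM in this assay, at which 1 of the 2 values shown sits, and the limit of > 50000 nM in this assay, at which 1 of the 2 values shown sits, are both limits, so neither value fixes a number for compound 1 in this assay.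

Compound 3 `O=C(Nc1cccc(-n2cc(-c3ccncc3)c(-c3ccc(Cl)c(O)c3)n2)c1)Nc1ccc(Cl)c(C(F)(F)F)c1` is the next compound of the series. Its difference from compound 1 is chloro in place of hydrogen on an aromatic carbon, on the ring carrying the trifluoromethyl group. Among the measured compounds shown here, no measured step bears on this change; the only measured step, from compound 1 to compound 2, sits elsewhere and is itself unreadable. With both measured values at limits and no readable step, compound 3 is expected to report a limit as well rather than a number, and the expected step that the limit leaves unreadable from compound 1 to compound 3 is set at none beyond the scatter. Compound 3 is therefore estimated at 40000 nM, with a range from 12000 nM to 120000 nM.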

Compound 3, concentration lethal to 50% of the cells: 13500 nM
The estimate for compound 3 lay 3.0-fold (0.47 log units) above the measured number, and the stated range covers the measured number.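

In this assay, among these compounds, the chloro on the ring carrying the trifluoromethyl group, placed ortho to a trifluoromethyl group and para to a large group, gives an at least 2.4-fold lower number from compound 1 to compound 3 (0.38 log units; beyond the scatter) and so provides the first step with a readable size. The earlier change, methyl in place of hydrogen on an oxygen on an aromatic ring, cannot be read, which leaves this position as the only place among the compounds shown where a change has a size, and compound 3 at 13500 nM as the only value that is a number and not a limit. The size printed for the chloro step is a minimum, and its full size stays unfixed because compound 1 stands at a limit: the limit of > 32500 nM in this assay, at which 1 of the 3 values shown sits.

Going by these compounds, whether the step belongs to chloro itself, or would also appear with a bromo or an amine at the same place, stays open. Also open, on these data alone, is whether the same chloro would give a comparable step on compound 2, which carries the methyl on the oxygen.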